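Swapping the aryloxy group on a peptidomimetic

The source may hold more compounds than are shown below. What is called first, only, known or untested is meant among the compounds shown, and "the series" means these compounds.

Compound 1: `CC(C)[C@H](NC(=O)COc1cccc2ccccc12)C(=O)N[C@@H](CC(=O)O)C(=O)COc1cc(C(F)(F)F)cc(C(F)(F)F)c1` — > 100000 nM
Compound 2: `CC(=O)Nc1cccc(OCC(=O)[C@H](CC(=O)O)NC(=O)[C@@H](NC(=O)COc2cccc3ccccc23)C(C)C)c1` — > 100000 nM

Of the compounds shown here, two have so far been tested in a functional assay on Jurkat cells (Homo sapiens); a lower number here means a stronger inhibitor, a higher number a weaker inhibitor. In this assay compound 1 gives > 100000 nM, which is a limit of the assay and not a number. Compound 2 likewise gives > 100000 nM in this assay, again only a limit. Going by the values given here, compound 2 therefore stands at the limit of > 100000 nM in this assay, at which 2 of the 2 values shown sit, so nothing measured separates it from compound 1, and no step between measured compounds can be drawn.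

Compound 3, `CC(C)[C@H](NC(=O)COc1cccc2ccccc12)C(=O)N[C@@H](CC(=O)O)C(=O)COc1cc(F)c(F)cc1F`, has not yet been measured in this assay. It differs from compound 2 by 2,4,5-trifluorophenyl in place of 3-acetamidophenyl on an oxygen on a saturated carbon. Among the compounds with values here, since both measured values sit at the same limit, there is no measured step from which a direction for this change can be read, and neither compound 1 nor compound 2 shows any inhibition within the range of this assay.

Compound 3 is expected to behave like its two relatives, with an estimated step of a number no higher from compound 2 to compound 3 (the limit leaves the size open). The estimate for compound 3 in this assay is 100000 nM, within a range from 20000 nM to 300000 nM, and most likely the assay will again report only a limit.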

Compound 3, half-maximal inhibitory concentration: 39300 nM
Estimate against measurement, compound 3: 2.5-fold (0.41 log units) above; low and high end bracket the measured number.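

Going by these compounds alone, putting 2,4,5-trifluorophenyl in place of 3-acetamidophenyl on an oxygen on a saturated carbon gives an at least 2.5-fold lower number from compound 2 to compound 3 (0.40 log units; beyond the scatter) in this assay, the first step in this small set that can be read. With compound 3 at 39300 nM, the group on this oxygen is shown to be able to bring the series into the measurable range of this assay, which the earlier pair could not show, both of them sitting at one limit: the limit of > 100000 nM in this assay, at which 2 of the 3 values shown sit. Compound 1, whose ring carries trifluoromethyl groups, gives > 100000 nM, which is a limit of the assay and not a number, so fluorine-bearing groups on this ring do not by themselves yield a measurable value.

On these data alone, how large the step from compound 2 really is stays unknown, and so does which of the three fluorines on the ring of compound 3 matters, if any one does alone. Whether an unsubstituted phenyl, a chlorine-bearing phenyl or a nitrile-bearing phenyl on this oxygen would give a lower number than compound 3 is also left open.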